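The compounds below may be only part of what the source reports. "The series", "measured", "known", "first", "only" and "open" are said of these compounds alone.

Measured compounds:
Compound 1, `CC(C)c1cccc2nc(N3CCN(C)CC3)oc12`. In a functional assay on ileum (strain Hartley) for agonist activity at 5-hydroxytryptamine receptor 3A (Cavia porcellus) (a higher number here means a more potent compound, by a factor of ten per unit of this negative logarithm, a lower number a less potent compound), compound 1 gives < 4, which is a limit of the assay rather than a number.
Compound 2, `CN1CCN(c2nc3cccc(Cl)c3o2)CC1`. In this assay compound 2 gives 5.5.
Compound 3, `CN1CCN(c2nc3cc(C(C)(C)C)ccc3o2)CC1`. In this assay compound 3 gives < 4, again a limit of the assay.

Compound 2 therefore stands alone: it carries the only number in this assay, while the two other values are limits, as shown by the limit of < 4 in this assay, at which 2 of the 3 values shown sit. Within the data shown here, the one measured step is a number at least 1.50 log units higher from compound 1 to compound 2 (beyond the scatter), a large change that concerns chloro in place of isopropyl on an aromatic carbon.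

The unmeasured compound 4, `Cc1cc(Cl)c2oc(N3CCN(C)CC3)nc2c1`, differs from compound 2 by methyl in place of hydrogen on an aromatic carbon. The change from compound 2 to compound 4 is the entry of a methyl in place of hydrogen on an aromatic carbon of the six-membered ring of the fused system, while the chloro group is kept. Among the measured compounds shown here, no measured step concerns a methyl entering on that ring, so the step from compound 1 to compound 2 does not bear directly on it. With the chloro retained, the expectation is for no step beyond the scatter in this assay, that is no change at the digits printed from compound 2 to compound 4 (within the scatter). Compound 4 is accordingly expected to give about 5.5, with a range from 4.8 to 6.2.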

Compound 4, negative logarithm of the half-maximal effective concentration: 6.22
The estimate for compound 4 lay 0.72 log units below the measured number; measured number outside the range, above it.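

In this assay, the methyl in place of hydrogen on an aromatic carbon, meta to a chloro group and para to a fused ring, gives a number 0.72 log units higher from compound 2 to compound 4 (beyond the scatter). Among these compounds, the only earlier step in one place concerned the chloro group itself, a number at least 1.50 log units higher from compound 1 to compound 2 (beyond the scatter); this one shows that, with chloro kept, a second site on the same six-membered aromatic ring can also move the number, and that adding a methyl there leaves compound 4 with a number and not a limit. Nothing given here accounts for this gain.

The compounds shown leave open whether the gain is particular to methyl or would also appear with an ethyl, a methoxy group or an amine on the same carbon, and whether methyl would bring any gain at all without the chloro group. Any reading of the wider series also stays narrow, with only two numbers so far and the rest of the values set at a limit: the limit of < 4 in this assay, at which 2 of the 4 values shown sit.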